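The source may report more compounds than this note shows. Statements on the series, on what has been measured and on what is new or still open speak of the compounds shown alone.

Compound 1 `COc1ccc(-c2cc3ccccc3nc2C=O)cc1`: > 10000 nM
Compound 2 `COc1ccc(-c2cc3ccccc3nc2/C=C/C(=O)c2cccs2)cc1`: 5440 nM

Within the data shown here, in a functional assay on NCI-H460 cells (Homo sapiens) for antiproliferative activity, read by XTT assay, with a stated time of 72 h (a higher number here means a weaker inhibitor, a lower number a stronger inhibitor), compound 2 gives 5440 nM, the only number measured here. For compound 1 the reading of > 10000 nM is a limit of the assay and not a number (the limit of > 10000 nM in this assay, at which 1 of the 2 values shown sits). Among the measured compounds shown here, the one measured step, an at least 1.8-fold lower number from compound 1 to compound 2 (0.26 log units; that floor lies within the scatter), swaps a formyl for the whole enone side chain and so does not touch the part changed next. Compound 3 `COc1ccc(-c2cc3ccccc3nc2/C=C/C(=O)c2ccc[nH]2)cc1` differs from compound 2 by 1H-pyrrol-2-yl in place of thiophen-2-yl on a carbonyl carbon. For the measured compounds named here, no measured step bears on this swap, so no change beyond the scatter is expected: compound 3 is estimated at 5400 nM, between 1800 nM and 16000 nM, a step of a 1.0-fold lower number from compound 2 to compound 3 (0.00 log units; within the scatter).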

Compound 3, half-maximal inhibitory concentration: > 10000 nM
Compound 3 ended at the assay's limit; the forecaster's own chance of this, stated with the estimate: 20%; at least 1.8-fold (0.26 log units) between middle value and limit.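

Placing 1H-pyrrol-2-yl in place of thiophen-2-yl on the carbonyl carbon is the first change shown within the enone side chain, and it gives an at least 1.8-fold higher number from compound 2 to compound 3 (0.26 log units; that floor lies within the scatter). Nothing in this assay therefore shows a gain from this swap, though its floor does not separate the two compounds beyond the scatter. The step from compound 1 to compound 3 cannot be read, since both ends are limits and not numbers: the limit of > 10000 nM in this assay, at which 2 of the 3 values shown sit.

On these data alone, how far compound 3 truly lies from compound 2 stays open. So does what a furan-2-yl or phenyl ring on this carbonyl carbon would give.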